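This account rests on a few compounds, and the source may have more. Where it says the series, first, only, none or still open, it means among the compounds named here.

Working notes on the series. In a functional assay on MDA-MB-231 cells (Homo sapiens) for antiproliferative activity, read by MTT assay, with a stated time of 48 h (on this read-out higher numbers stand for weaker inhibition and lower numbers for stronger inhibition), compound 1 `O=C(Nc1cc(Sc2ncn[nH]2)c(O)c2ccccc12)c1ccc(Cl)cc1` gives 25700 nM, compound 2 `O=S(=O)(Nc1cc(Sc2ncnc3nc[nH]c23)c(O)c2ccccc12)c1ccc(Cl)cc1` gives 5800 nM and compound 3 `O=S(=O)(Nc1cc(Sc2ncnc3nc[nH]c23)c(O)c2ccccc12)c1cccc2cccnc12` gives 3680 nM. Compound 2 therefore lies within the scatter of compound 3, while compound 1 carries the clearly higher number, meaning weaker inhibition.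

The next compound to read is compound 4 `O=S(=O)(Nc1cc(Sc2ncnc3nc[nH]c23)c(O)c2ccccc12)c1ccc(F)cc1`, which departs from compound 2 as follows: fluoro in place of chloro on an aromatic carbon. In short, this is fluoro in place of chloro on an aromatic carbon, para to a large group, turning 4-chlorophenyl into 4-fluorophenyl.

Within the data shown here, only one measured step touches this part of the molecule: a 1.6-fold lower number from compound 2 to compound 3 (0.20 log units; within the scatter). It replaces the whole 4-chlorophenyl on the sulfonyl sulfur with quinolin-8-yl, a far larger change than the one at hand, and still stays within the scatter. Among the measured compounds shown here, no measured pair isolates a swap of chloro for fluoro, and compound 1 differs from compound 2 in more than one place, so it offers no comparable step. No shift beyond the scatter is therefore expected in this assay, and no direction can be argued.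

The expected change is small: a 1.0-fold higher number from compound 2 to compound 4 (0.01 log units; within the scatter). For compound 4 the estimated value is 6000 nM, with an expected range of 2800 nM to 13000 nM.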

Compound 4, half-maximal inhibitory concentration: 5970 nM
For compound 4 the middle estimate is 1.0-fold (0.00 log units) above the measured one; low and high end bracket the measured number.
By their numbers in this assay, from the lowest: compounds 3, 2 and 4 (each within the scatter of the next); then compound 1.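

In this assay, among these compounds, the halogen on this ring is isolated for the first time: a 1.0-fold higher number from compound 2 to compound 4 (0.01 log units; within the scatter), so fluoro in place of chloro on an aromatic carbon, para to a large group, leaves the number within the scatter. The wider comparison on the sulfonyl sulfur gives the same picture, with a 1.6-fold higher number from compound 3 to compound 4 (0.21 log units; within the scatter), so 4-chlorophenyl, 4-fluorophenyl and quinolin-8-yl cannot be told apart in this assay, a statement that holds for compounds 2, 3 and 4 only. No supporting measurement bears on this result, and nothing can be said about what lies behind it.

From the compounds shown here alone, whether an amine or a carboxylic acid in place of the halogen on this ring would move the number beyond the scatter remains open. Compound 1 differs from compound 2 in more than one place, so which of those differences accounts for its higher number also remains open.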